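The source may hold more compounds than are shown below. What is called first, only, known or untested is meant among the compounds shown, and "the series" means these compounds.

Measured so far in an ADME assay on HEK-293T cells (Homo sapiens) for cytotoxicity, read by CCK-8 assay, with a stated time of 48 h; a higher number here means a weaker inhibitor, a lower number a stronger inhibitor:
compound 1, `Cc1ccc(-c2ccsc2S(=O)(=O)NCCNC(=O)Nc2cc(C(F)(F)F)cc(C(F)(F)F)c2)c(Oc2ccc(O)c(O)c2)c1`, gives > 20000 nM, a limit of the assay.
compound 2, `CC(C)c1ccc(Oc2ccc(O)c(O)c2)c(-c2ccsc2S(=O)(=O)NCCNC(=O)Nc2cc(C(F)(F)F)cc(C(F)(F)F)c2)c1`, gives > 20000 nM, likewise a limit.
compound 3, `COc1ccc(Oc2cc(C)ccc2-c2ccsc2S(=O)(=O)NCCNC(=O)Nc2cc(C(F)(F)F)cc(C(F)(F)F)c2)cc1OC`, gives 9000 nM.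

The difference between the cores of compound 1 and compound 2 is not broken down here. From compound 1 to compound 3 the change is 3,4-dimethoxyphenyl in place of 3,4-dihydroxyphenyl on an oxygen on an aromatic ring. It gave an at least 2.2-fold lower number from compound 1 to compound 3 (0.34 log units; beyond the scatter). That step is known only as a bound, because compound 1 sits at the limit of > 20000 nM in this assay, at which 2 of the 3 values shown sit.

Compound 4, `COc1ccc(Oc2ccc(C(C)C)cc2-c2ccsc2S(=O)(=O)NCCNC(=O)Nc2cc(C(F)(F)F)cc(C(F)(F)F)c2)cc1OC`, is not yet measured. From compound 2 it carries the same change, (3,4-dimethoxyphenyl in place of 3,4-dihydroxyphenyl on an oxygen on an aromatic ring), at a place with the same neighbours. In this assay the step is expected to be an at least 2.2-fold lower number from compound 2 to compound 4 (0.34 log units; beyond the scatter), resting on an at least 2.2-fold lower number from compound 1 to compound 3 (0.34 log units; beyond the scatter), with the caution that compound 2 is itself only a limit. Compound 4 is expected near 9000 nM, between 4000 nM and 20000 nM.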

Compound 4, half-maximal inhibitory concentration: 12100 nM
Beside the measured number, compound 4's estimate is 1.3-fold (0.13 log units) below it; measured number inside the range.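

In this assay, 3,4-dimethoxyphenyl in place of 3,4-dihydroxyphenyl gives an at least 1.6-fold lower number from compound 2 to compound 4 (0.21 log units; that floor lies within the scatter), so the change carries to the core of compound 2 in the same direction as on the core of compound 1, but this floor alone does not clear the scatter. Compound 2 gives > 20000 nM, which is a limit of the assay, so the step on this core is known only as a floor. Whether the change is worth the same on the two cores cannot be read: the same change on two cores in this assay, an at least 2.2-fold lower number (0.34 log units; beyond the scatter) from compound 1 to compound 3 and an at least 1.6-fold lower number (0.21 log units; that floor lies within the scatter) from compound 2 to compound 4; the limit leaves it open whether they differ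

The compounds shown leave open how far the number moves on either core once the limit is removed. They also leave open what a carboxylic acid or an amine would do on the ring now carrying the two methoxy groups.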